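Amide chain extension on two anilide cores

A few compounds are considered here, and "the series" means these few. Any claim that something is new, unique, unknown or untested is made for them only; others in the source may bear on it.

Compound 1 `CCCC(=O)N1N=C(c2cc(Cl)ccc2N)SC1(C)C` gives 66.2% in an assay on isolated protein for inhibition of Nitric oxide synthase, inducible (Homo sapiens), read by scintillation counting, with a stated time of 30 min, tested at 50 uM; a higher number here means more inhibition at the concentration tested (going by the name of the read-out), a lower number less inhibition. Compound 2 `CCCCC(=O)N1N=C(c2cc(Cl)ccc2N)SC1(C)C` differs from it by methyl in place of hydrogen on a saturated chain carbon, three bonds along the chain from a carbonyl carbon; in this assay compound 2 gives 12.6%, a step of a number 53.6 percentage points lower from compound 1 to compound 2 (beyond the scatter). Compound 3 `CCCC(=O)N1N=C(c2ccccc2N)SC1(C)C` carries the core difference hydrogen in place of chloro on an aromatic carbon relative to compound 1; in this assay compound 3 gives 35.2%, a step of a number 31 percentage points lower from compound 1 to compound 3 (beyond the scatter). Compound 4 `CCCCC(=O)N1N=C(c2ccccc2N)SC1(C)C` is not yet measured; it differs from compound 3 by methyl in place of hydrogen on a saturated chain carbon, three bonds along the chain from a carbonyl carbon, the same change as from compound 1 to compound 2, at the same place, now on the core of compound 3. For compound 4 in this assay a step of a number 29.2 percentage points lower from compound 3 to compound 4 (beyond the scatter) is expected, smaller than the earlier step only because compound 3 starts from 35.2% and the read-out cannot fall much below zero. Compound 4 is thus estimated at 6%, between -5% and 20%.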

Compound 4, a percentage reported as inhibition, at one concentration (the size of the read-out at that concentration, not a potency): 39.1%
Estimate against measurement, compound 4: 33.1 percentage points below; the measured number lies above the stated range.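

In this assay, methyl in place of hydrogen gives a number 3.9 percentage points higher from compound 3 to compound 4 (within the scatter), so the large drop seen on the core of compound 1 does not carry over to the core of compound 3: the same change on two cores in this assay, a number 53.6 percentage points lower (beyond the scatter) from compound 1 to compound 2 and a number 3.9 percentage points higher (within the scatter) from compound 3 to compound 4, 57.5 percentage points apart, beyond the scatter of two such steps

Read the other way, hydrogen in place of chloro gives a number 26.5 percentage points higher from compound 2 to compound 4 (beyond the scatter), so the direction of this step depends on the chain: the same change on two cores in this assay, a number 31 percentage points lower (beyond the scatter) from compound 1 to compound 3 and a number 26.5 percentage points higher (beyond the scatter) from compound 2 to compound 4, 57.5 percentage points apart, beyond the scatter of two such steps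

A single pair of cores and chains, read at one concentration, shows that this change is not transferable here, but gives no rule for other cores and no measure of potency.

Still open, as far as these compounds go, is whether a longer chain such as hexanoyl follows the pentanoyl or the butanoyl pattern. Also open, from the compounds shown here alone, is how bromo or methoxy in place of chloro would behave.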